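The compounds below may be only part of what the source reports. "The series", "measured", "known", "first", "only" and "open" are said of these compounds alone.

Measured in a functional assay on MCF7 cells (Homo sapiens) for inhibition, with a stated time of 96 h; on this read-out higher numbers stand for weaker inhibition and lower numbers for stronger inhibition:
- compound 1 `COc1cc(C(=O)c2cn(-c3cccc(C)c3)cc2-c2ccsc2)cc(OC)c1OC`: 65 nM
- compound 2 `COc1cc(C(=O)c2cn(-c3cccc(C)c3)cc2-c2ncco2)cc(OC)c1OC`: 75 nM
- compound 3 `COc1cc(C(=O)c2cn(-c3ccc(C)cc3)cc2-c2ccsc2)cc(OC)c1OC`: 4 nM

Compound 3 has the lowest number of the three, and its gaps to both others lie beyond the scatter. Compound 4 `COc1cc(C(=O)c2cn(-c3ccc(C)cc3)cc2-c2nccs2)cc(OC)c1OC` keeps the 4-methylphenyl group of compound 3 and carries 1,3-thiazol-2-yl in place of thiophen-3-yl on an aromatic carbon.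

For the measured compounds named here, two measured steps bear on this change. The closest is a 1.2-fold higher number from compound 1 to compound 2 (0.06 log units; within the scatter), where 1,3-oxazol-2-yl replaces thiophen-3-yl on the same carbon, and it stays within the scatter. That step was measured with 3-methylphenyl, however, and the exchange of that group for 4-methylphenyl gives a large step, a 16-fold lower number from compound 1 to compound 3 (1.21 log units; beyond the scatter). A flat result in the one background may therefore not carry over to the other. Going by the values given here, no measured compound contains 1,3-thiazol-2-yl, and no exchange on this carbon has been measured with 4-methylphenyl.

A small change is the most likely outcome in this assay, with a modest lean towards a higher number, and a wide margin is warranted. The estimate is a 2.5-fold higher number from compound 3 to compound 4 (0.40 log units; beyond the scatter). Compound 4 is expected at about 10 nM, with an estimated range of 3 nM to 40 nM.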

Compound 4, half-maximal inhibitory concentration: 14 nM
Beside the measured number, compound 4's estimate is 1.4-fold (0.15 log units) below it; measured number inside the range.
By their numbers in this assay, from the lowest: compound 3; then compound 4; then compounds 1 and 2 (each within the scatter of the next).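

With the 4-methylphenyl group held fixed, 1,3-thiazol-2-yl in place of thiophen-3-yl gives a 3.5-fold higher number from compound 3 to compound 4 (0.54 log units; beyond the scatter) in this assay, the only exchange on this aromatic carbon shown to lie beyond the scatter. The other exchange here, with 1,3-oxazol-2-yl and 3-methylphenyl, stays within it (a 1.2-fold higher number from compound 1 to compound 2 (0.06 log units; within the scatter)), so this carbon is not indifferent to every exchange of its five-membered aromatic ring, though the two steps differ in both the entering ring and the methylphenyl group. No supporting data bear on why the thiazole exchange moves the number.

Open is whether the size of the step depends on the methylphenyl group, since the compounds shown do not pair 1,3-oxazol-2-yl with 4-methylphenyl or 1,3-thiazol-2-yl with 3-methylphenyl. Also open is how this carbon responds to groups outside the five-membered aromatic rings shown, such as an unsubstituted phenyl ring, an amine or a carboxylic acid.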